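The source may report more compounds than this note shows. Statements on the series, on what has been measured and on what is new or still open speak of the compounds shown alone.

Measured compounds in this series:
compound 1 `O=S(=O)(NCC1CCN(CCCc2c[nH]c3ccc(-n4cnnc4)cc23)CC1)c1ccccc1` – 60 nM
compound 2 `c1ccc(C2CCCCN2C2CCN(CCCc3c[nH]c4ccc(-n5cnnc5)cc34)CC2)cc1` – 410 nM
compound 3 `CC(=O)Nc1ccc([C@H](C)NCC2CCN(CCCc3c[nH]c4ccc(-n5cnnc5)cc34)CC2)cc1` – 9.3 nM

All three share the same core and differ only in the group carried on the saturated ring. In an assay on CHO cells for displacement of a labelled ligand from 5-hydroxytryptamine receptor 1B (Homo sapiens) (on this read-out lower numbers stand for stronger inhibition and higher numbers for weaker inhibition), compound 1 sits second highest of the three numbers; its nearest neighbour is compound 3, which gives 9.3 nM, and the furthest is compound 2, which gives 410 nM. For the measured compounds named here, the one step that can be followed directly is a 6.5-fold lower number from compound 1 to compound 3 (0.81 log units; beyond the scatter), where a secondary amine with an aryl-bearing substituent replaces the sulfonamide.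

The unmeasured compound 4 `CN(Cc1ccco1)C1CCN(CCCc2c[nH]c3ccc(-n4cnnc4)cc23)CC1` changes compound 1 as follows: ((furan-2-yl)methyl)(methyl)amino in place of ((phenylsulfonyl)amino)methyl on a saturated ring carbon. This differs from the step to compound 3 in two ways: the amine becomes tertiary and sits directly on the ring carbon, and the aromatic part is a smaller five-membered ring. Compound 2, which also places a nitrogen directly on that ring carbon, shows the weakest number of the three. So the single relevant step points downward, while the values of compound 2 point upward, and no clear expectation beyond the scatter follows. Compound 4 is therefore expected to land near compound 1, with an estimated step of a 1.8-fold higher number from compound 1 to compound 4 (0.26 log units; within the scatter) and an expected value of 110 nM in this assay, ranging from 35 nM to 350 nM.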

Compound 4, half-maximal inhibitory concentration: 89 nM
Compound 4: the middle estimate sits 1.2-fold (0.09 log units) above what was measured; low and high end bracket the measured number.
By their numbers in this assay, from the lowest: compound 3; then compounds 1 and 4 (each within the scatter of the next); then compound 2.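

In this assay, the exchange at this saturated ring carbon gives a 1.5-fold higher number from compound 1 to compound 4 (0.17 log units; within the scatter) even though the two substituents share little: ((furan-2-yl)methyl)(methyl)amino has a five-membered aromatic ring and no hydrogen-bond donor, while ((phenylsulfonyl)amino)methyl has a six-membered aromatic ring of carbon only and one hydrogen-bond donor. For this pair, neither the sulfonyl group nor a hydrogen-bond donor in the substituent is needed to keep the number at this level. No evidence is available on why the two substituents read alike.

Going by these compounds, what the furan ring and the methyl group each contribute remains open; a phenyl in place of the furan-2-yl, or a hydrogen in place of the methyl on the amine nitrogen, would separate them. Also open, on these data alone, is whether the 1-(4-acetamidophenyl)ethyl group keeps its number when its amine sits directly on the saturated ring carbon.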